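From 2-fluorophenyl to 4-chlorophenyl: One Untested Exchange

This account rests on a few compounds, and the source may have more. Where it says the series, first, only, none or still open, it means among the compounds named here.

In an ADME assay on L02 cells (Homo sapiens) for cytotoxicity, read by MTT assay, with a stated time of 24 h (on this read-out lower numbers stand for stronger inhibition and higher numbers for weaker inhibition), compound 1 `CN1C/C(=C\c2cccc([N+](=O)[O-])c2)C(=O)/C(=C/c2ccccc2F)C1` gives 13500 nM, compound 2 `COc1cc(/C=C2\CN(C)C/C(=C\c3ccc(C#N)cc3)C2=O)cc(OC)c1` gives 14000 nM and compound 3 `COc1cc(/C=C2\CN(C)C/C(=C\c3ccc(C#N)cc3)C2=O)cc(OC)c1OC` gives 18600 nM. These three numbers all lie within the usual scatter of one another, so compound 1 stands level with the other two and the data set no order among them.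

Compound 4 `CN1C/C(=C\c2ccc(Cl)cc2)C(=O)/C(=C/c2cccc([N+](=O)[O-])c2)C1` has not yet been measured. It differs from compound 1 in one place, with 4-chlorophenyl in place of 2-fluorophenyl on a double-bonded chain carbon bound to a double-bonded ring carbon.

Within the data shown here, only one measured step links two compounds that differ in a single place: a 1.3-fold higher number from compound 2 to compound 3 (0.12 log units; within the scatter). That step puts methoxy in place of hydrogen on an aromatic carbon, so it is a different change and offers only indirect guidance. Among the measured compounds shown here, no measured pair shows what happens when 2-fluorophenyl is exchanged for 4-chlorophenyl, which leaves the estimate uncertain. For the measured compounds named here, still, the only measured step stays within the scatter, and the three measured compounds sit close together despite their different aromatic groups.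

No shift beyond the scatter is therefore expected in this assay, and the expected step is a 1.0-fold higher number from compound 1 to compound 4 (0.02 log units; within the scatter). Compound 4 is estimated at 14000 nM, with an expected range from 7000 nM to 28000 nM.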

Compound 4, half-maximal inhibitory concentration: > 20000 nM
Compound 4: a limit, no number (the forecaster's own chance of this, stated with the estimate: 5%); middle value at least 1.4-fold (0.15 log units) from the limit.
By their numbers in this assay, from the lowest: compounds 1, 2 and 3 (each within the scatter of the next). At a limit, above all of these: compound 4.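

In this assay, putting 4-chlorophenyl in place of 2-fluorophenyl on a double-bonded chain carbon bound to a double-bonded ring carbon gives an at least 1.4-fold higher number from compound 1 to compound 4 (0.17 log units; that floor lies within the scatter). Among these compounds, this is the first measured exchange at this position, and the floor of the step lies within the scatter, so the data show no lower number for the 4-chlorophenyl compound but fix no size for the step. The value of compound 4 is a limit and not a number, and it is the only such value in the set: the limit of > 20000 nM in this assay, at which 1 of the 4 values shown sits.

The exchange alters two things at once, the halogen on the ring and the place of that halogen in the group's name, and the compounds shown do not separate them, since neither 2-chlorophenyl nor 4-fluorophenyl stands among them. Also open is how the same position would read with a phenyl ring carrying an amine or a carboxylic acid, groups that none of the compounds shown contains at this place.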